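The source may hold more compounds than are shown below. What is called first, only, known or untested is meant among the compounds shown, and "the series" means these compounds.

Compound 1 `O=C(Nc1ccc(Sc2nc3ccccc3s2)c(Cl)c1)c1cc(Br)cc(Br)c1` gives in an assay for inhibition of HSP60/HSP10 (Homo sapiens), with a stated time of 60 min (on this read-out lower numbers stand for stronger inhibition and higher numbers for weaker inhibition), a limit of the assay, > 100000 nM.
Compound 2 `COc1c(Br)cc(Br)cc1C(=O)Nc1ccc(Sc2nc3ccccc3s2)c(Cl)c1` gives in this assay likewise a limit, > 100000 nM.
Compound 3 `COc1c(Br)cc(Br)cc1C(=O)Nc1cccc(Cl)c1` gives in this assay again a limit, > 100000 nM.

Compound 2 thus stands at the limit of this assay, as do the two other measured compounds; (the limit of > 100000 nM in this assay, at which 3 of the 3 values shown sit). Compound 4 `COc1c(Br)cc(Br)cc1C(=O)Nc1ccc(Sc2nc3ccccc3s2)cc1` differs from compound 2 by hydrogen in place of chloro on an aromatic carbon. The two measured steps that touch compound 2, a step that the two limits leave unreadable from compound 1 to compound 2 and a step that the two limits leave unreadable from compound 2 to compound 3, both run between limits, so neither their size nor their direction can be read. Within the data shown here, no measured step therefore bears on the change from compound 2 to compound 4, and the step that the limit leaves unreadable from compound 2 to compound 4 is expected to remain unreadable in the same way. Compound 4 is expected to give in this assay about 150000 nM, within 50000 nM to 1000000 nM, most probably again as a limit.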

Compound 4, half-maximal inhibitory concentration: > 100000 nM
Compound 4 gave a limit, no number; the forecaster's own chance of this, stated with the estimate: 85%; the middle value lies beyond the limit too.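

Compound 2 and compound 4 both stand at a limit in this assay, and the step between them cannot be read. The compounds shown leave open whether chloro affects inhibition and which structure would give a measurable value in this assay.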